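A few compounds are considered here, and "the series" means these few. Any claim that something is new, unique, unknown or untested is made for them only; others in the source may bear on it.

Compound 1, with the structure `COc1ccc(N(C)c2ccnc(Cl)n2)cc1[N+](=O)[O-]`, is tested in a functional assay on HeLa cells (Homo sapiens) for antiproliferative activity, read by MTT assay, with a stated time of 48 h (on this read-out higher numbers stand for weaker inhibition and lower numbers for stronger inhibition), where compound 1 gives 4730 nM. Compound 2, `COc1ccc(N(C)c2ccnc(Cl)n2)cc1O`, differs from it by a single change, (hydroxy in place of nitro on an aromatic carbon), and in this assay compound 2 gives 96 nM; the step is a 49-fold lower number from compound 1 to compound 2 (1.69 log units; beyond the scatter). Compound 3, `COc1ccc(N(C)c2cc(C)nc(C)n2)cc1[N+](=O)[O-]`, carries a different core; how its core differs from that of compound 1 is not broken down here. In this assay compound 3 gives 3720 nM. Compound 4, `COc1ccc(N(C)c2cc(C)nc(C)n2)cc1O`, is the not yet measured partner of compound 3: the change between them is hydroxy in place of nitro on an aromatic carbon. The surroundings of the place are not described in the same words, meta to a large group here against meta to a group of 9 heavy atoms before, so this is the same kind of change rather than the same change. Beside the earlier step, the step from compound 3 to compound 4 is expected to be a 41-fold lower number from compound 3 to compound 4 (1.62 log units; beyond the scatter), an expectation that rests on compound 1 and compound 2, whose step a 49-fold lower number from compound 1 to compound 2 (1.69 log units; beyond the scatter) was large. For compound 4 the expected value is 90 nM, with a range from 30 nM to 300 nM.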

Compound 4, half-maximal inhibitory concentration: 93 nM
Compound 4: the middle estimate sits 1.0-fold (0.01 log units) below what was measured; low and high end bracket the measured number.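

In this assay putting hydroxy in place of nitro gives a 40-fold lower number from compound 3 to compound 4 (1.60 log units; beyond the scatter) and this matches what the same change did on the other core: the same change on two cores in this assay, a 49-fold lower number (1.69 log units; beyond the scatter) from compound 1 to compound 2 and a 40-fold lower number (1.60 log units; beyond the scatter) from compound 3 to compound 4, 1.2-fold (0.09 log units) apart, within the scatter of two such steps. On these two cores, then, the change carried over with its size intact, and the difference between the cores did not alter it. This does not show that it would carry over to a core unlike these two, and two pairs of compounds cannot explain why hydroxy gives the lower number.

The compounds shown leave open whether hydroxy is specifically needed at this place or whether another group, such as an amine or a carboxylic acid, would serve as well. They also leave open whether the step would hold on other cell types.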